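Methoxy to hydroxy on the shared core

This account rests on a few compounds, and the source may have more. Where it says the series, first, only, none or still open, it means among the compounds named here.

Compound 1 `COc1ccc(/C=C2\N=C3C=CC=CN3C2=O)cc1`: 60 nM
Compound 2 `O=C1/C(=C/c2ccc(Br)cc2)N=C2C=CC=CN12`: 45 nM

Within the data shown here, in a functional assay on HEK-293T cells (Homo sapiens) for inhibition, read by MTT assay, with a stated time of 48 h (a higher number here means a weaker inhibitor, a lower number a stronger inhibitor), compound 1 stands level, within the scatter, with compound 2, the only other compound measured. Compound 3 `O=C1/C(=C/c2ccc(O)cc2)N=C2C=CC=CN12` differs from compound 1 in one place: hydrogen in place of methyl on an oxygen on an aromatic ring, which reads as methoxy to hydroxy. Among the measured compounds shown here, the one measured step that bears on this, a 1.3-fold lower number from compound 1 to compound 2 (0.12 log units; within the scatter), also replaces the methoxy group and stays within the scatter. It is a different change, so it guides only loosely, and no step beyond the scatter is expected in this assay. The expected step is a 1.1-fold lower number from compound 1 to compound 3 (0.04 log units; within the scatter). Compound 3 is estimated at 55 nM, with an expected range from 18 nM to 170 nM.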

Compound 3, half-maximal inhibitory concentration: 40 nM
Compound 3: the middle estimate sits 1.4-fold (0.14 log units) above what was measured; low and high end bracket the measured number.
By their numbers in this assay, from the lowest: compounds 3, 2 and 1 (each within the scatter of the next).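

In this assay, a hydroxy group on this aromatic carbon stands level with methoxy (a 1.5-fold lower number from compound 1 to compound 3 (0.18 log units; within the scatter)) and with bromo (a 1.1-fold lower number from compound 2 to compound 3 (0.05 log units; within the scatter)). Across these three compounds, then, the place accepts a free hydroxy as well as its methyl ether or a halogen, with no step beyond the scatter. Nothing measured here accounts for this level standing. On these data alone, whether an amine or a carboxylic acid on the same aromatic carbon would stay level with these three remains open. So does the effect of any change elsewhere on the shared core.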